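Flipping the Double Bond: From Compound 1 to Compound 4

The source may hold more compounds than are shown below. What is called first, only, known or untested is meant among the compounds shown, and "the series" means these compounds.

Three compounds sharing one core were tested in a toxicity assay on the whole organism (strain Icem-CET (SPF Caw)) for cytotoxicity, with Mus musculus as the target; on this read-out lower numbers stand for an effect already at smaller amounts and higher numbers for an effect only at larger amounts of compound. Compound 1 `C/C(C(=O)NC1CC1)=C(\C)c1ccc(Br)cc1` gives 450 mg/kg; compound 2 `C/C(C(=O)NC1CC1)=C(\C)c1ccc(C)cc1` gives 500 mg/kg; compound 3 `C=CCNC(=O)/C(C)=C(/C)c1ccc(Cl)cc1` gives 280 mg/kg. Compound 1 thus stands second highest of the three, with compound 2 nearest and compound 3 furthest. Going by the values given here, the only step between single-point neighbours, a 1.1-fold higher number from compound 1 to compound 2 (0.05 log units; within the scatter), puts methyl in place of bromo on an aromatic carbon. Compound 4 `C/C(C(=O)NC1CC1)=C(/C)c1ccc(Br)cc1` differs from compound 1 as follows: the two compounds have the same atoms and bonds and differ only in configuration as drawn: 1 of 1 stereo elements differ; a double bond is drawn Z in compound 1 and E in compound 4. Among the compounds with values here, no measured step involves such a change of configuration; nothing here points to a shift in either direction, and the expected step in this assay is none beyond the scatter. Compound 4 is therefore estimated at 450 mg/kg, within 250 mg/kg to 800 mg/kg. The expected step is no change at the digits printed from compound 1 to compound 4 (within the scatter).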

Compound 4, dose for half-maximal effect: 600 mg/kg
Estimate against measurement, compound 4: 1.3-fold (0.12 log units) below, within the range that was stated.
By their numbers in this assay, from the lowest: compounds 3, 1, 2 and 4 (each within the scatter of the next, the first and the last beyond it).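

Drawing the double bond E instead of Z gives a 1.3-fold higher number from compound 1 to compound 4 (0.12 log units; within the scatter) in this assay, the first measured step at this bond. In this pair, the configuration of the double bond therefore has no effect that can be told apart from the scatter. This reading rests on a single pair, with one structural difference: the fact that compounds 1 and 4 differ only in the configuration as drawn

As far as these compounds go, whether the same holds with a carboxylic acid in place of the amide, or with an amine on the aromatic ring, stays open.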